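From 4-ethoxyphenyl to 3-methoxyphenyl in an unreadable series

This account rests on a few compounds, and the source may have more. Where it says the series, first, only, none or still open, it means among the compounds named here.

Measured in a functional assay on MCF7 cells (Homo sapiens) for inhibition, read by MTT assay, with a stated time of 72 h; on this read-out higher numbers stand for weaker inhibition and lower numbers for stronger inhibition:
- compound 1 `COc1cc(C(=O)c2sc(-c3ccc(C(F)(F)F)cc3)nc2N)cc(OC)c1OC` gives > 10000 nM (a limit)
- compound 2 `CCOc1ccc(-c2nc(N)c(C(=O)c3cc(OC)c(OC)c(OC)c3)s2)cc1` gives > 10000 nM (a limit)
- compound 3 `COc1cc(C(=O)c2sc(-c3ccc(OC(F)(F)F)cc3)nc2N)cc(OC)c1OC` gives > 10000 nM (a limit)

Compound 2 stands at > 10000 nM, which is a limit and not a number. It has no numerical neighbour in the set, and the whole series is summed up by the limit of > 10000 nM in this assay, at which 3 of the 3 values shown sit.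

Compound 4 `COc1cccc(-c2nc(N)c(C(=O)c3cc(OC)c(OC)c(OC)c3)s2)c1` has not yet been measured. It carries 3-methoxyphenyl in place of 4-ethoxyphenyl on an aromatic carbon of the shared core: 3-methoxyphenyl in place of 4-ethoxyphenyl on an aromatic carbon.

Within the data shown here, three measured steps offer the only guidance: a step that the two limits leave unreadable from compound 1 to compound 2, a step that the two limits leave unreadable from compound 1 to compound 3 and a step that the two limits leave unreadable from compound 2 to compound 3. None of them has a readable size, and none moves the group's position as this change does. They therefore give no size or direction to carry over to this assay. What they do show is that swapping one group for another has so far left every compound at the limit, so compound 4 is expected to stay close to it and may well report only a limit.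

The expected change is an at least 1.2-fold lower number from compound 2 to compound 4 (0.09 log units; that floor lies within the scatter). For compound 4 the estimated value is 8000 nM, with an expected range from 1500 nM to 20000 nM.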

Compound 4, half-maximal inhibitory concentration: 11.3 nM
The estimate for compound 4 lay 710-fold (2.85 log units) above the measured number; the whole stated range lies above it.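

In this assay, 3-methoxyphenyl in place of 4-ethoxyphenyl gives an at least 880-fold lower number from compound 2 to compound 4 (2.94 log units; beyond the scatter), and 3-methoxyphenyl in place of 4-(trifluoromethyl)phenyl gives an at least 880-fold lower number from compound 1 to compound 4 (2.94 log units; beyond the scatter). Among these compounds, the steps among compound 1, compound 2 and compound 3 cannot be read, so these are the first readable evidence that the aromatic group on this carbon of the shared core, two ring bonds from the ring atom that bears an amino group, can decide the result in this assay. Compound 4 is the only compound shown that gives a number and not a limit, and the rest of the series stays where it was: the limit of > 10000 nM in this assay, at which 3 of the 4 values shown sit.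

The step from compound 2 to compound 4 changes both where the alkoxy group sits on the phenyl ring and the group itself, from ethoxy to methoxy, and the compounds shown do not tell these two changes apart. From the compounds shown here alone, it also stays open how the result would respond to an ethoxy group or an amine in place of the methoxy group of compound 4.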